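Chloro for methyl on the aryl ring of compound 3

A few compounds are considered here, and "the series" means these few. Any claim that something is new, unique, unknown or untested is made for them only; others in the source may bear on it.

Compound 1 `Cc1ccc(-c2cc(N3CCC(CNS(N)(=O)=O)CC3)ncn2)cc1` gives 71000 nM in a functional assay on M21 cells (Homo sapiens) for antiproliferative activity, read by sulforhodamine B assay, with a stated time of 48 h; on this read-out higher numbers stand for weaker inhibition of growth and lower numbers for stronger inhibition of growth. Compound 2 `COc1ccccc1-c1cc(N2CCC(CNS(N)(=O)=O)CC2)ncn1` reaches only a limit, > 100000 nM in this assay, which is a limit and not a number (the limit of > 100000 nM in this assay, at which 1 of the 3 values shown sits). Compound 3 `Cc1ccc(-c2cc(N3CCC(CCNS(N)(=O)=O)CC3)ncn2)cc1` gives 57600 nM in this assay. Two steps are measured: an at least 1.4-fold higher number from compound 1 to compound 2 (0.14 log units; that floor lies within the scatter), and a 1.2-fold lower number from compound 1 to compound 3 (0.09 log units; within the scatter). Compound 3 therefore sits beside compound 1 with no separation beyond the scatter, while compound 2 contributes a limit.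

Compound 4 `NS(=O)(=O)NCCC1CCN(c2cc(-c3ccc(Cl)cc3)ncn2)CC1` differs from compound 3 by chloro in place of methyl on an aromatic carbon. Within the data shown here, no measured step exchanges one group for another on that aryl ring while keeping the rest fixed; the step of an at least 1.4-fold higher number from compound 1 to compound 2 (0.14 log units; that floor lies within the scatter) alters the aryl ring but ends at a limit, so it sets no size for a chloro-for-methyl swap. The chain step a 1.2-fold lower number from compound 1 to compound 3 (0.09 log units; within the scatter) does not touch the aryl ring. With nothing pointing either way, the expectation for compound 4 is a 1.2-fold lower number from compound 3 to compound 4 (0.06 log units; within the scatter), no step beyond the scatter. Compound 4 is accordingly estimated at 50000 nM, with a range of 20000 nM to 150000 nM in this assay.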

Compound 4, concentration for 50% growth inhibition: 45200 nM
Beside the measured number, compound 4's estimate is 1.1-fold (0.04 log units) above it, and the stated range covers the measured number.
By their numbers in this assay, from the lowest: compounds 4, 3 and 1 (each within the scatter of the next). At a limit, above all of these: compound 2.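

Chloro in place of methyl on the aromatic carbon para to a large group gives, in this assay, a 1.3-fold lower number from compound 3 to compound 4 (0.11 log units; within the scatter), the first step on this aryl ring that ends in a number at both compounds. At this position, then, 4-methylphenyl and 4-chlorophenyl cannot be told apart on this read-out, and the swap adds no separation to the chain step, which also stays within the scatter. No measurement shown bears on a cause for this step.

On these data alone, whether a group of another kind at the same carbon, such as an amine or a carboxylic acid, would give a step beyond the scatter remains open. Also open, as far as these compounds go, is whether a longer chain carrying the sulfamoylamino group would separate from compound 3 and compound 4 in this assay.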